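This account rests on a few compounds, and the source may have more. Where it says the series, first, only, none or still open, it means among the compounds named here.

Three compounds have been measured in a functional assay on thoracic aorta (strain Wistar) with Aorta (Rattus norvegicus) as the target, with a stated time of 2 h; a lower number here means a stronger inhibitor, a higher number a weaker inhibitor:

Compound 1 `CCOC(=O)c1c(-c2ccc(F)cc2)cc(-c2ccccc2)nc1Nc1ccc(OC)cc1` gives 254000 nM.
Compound 2 `CCOC(=O)c1c(-c2ccc(C)cc2)cc(-c2ccccc2)nc1Nc1ccc(OC)cc1` gives 233000 nM.
Compound 3 `CCOC(=O)c1c(-c2ccc(F)cc2)cc(-c2ccccc2)nc1N` gives 335000 nM.

All three numbers are high, and every gap between them lies within the usual scatter, so none of the three can be set apart from the others. The change from compound 1 to compound 2 is methyl in place of fluoro on an aromatic carbon; the step it made was a 1.1-fold lower number from compound 1 to compound 2 (0.04 log units; within the scatter). The change from compound 1 to compound 3 is hydrogen in place of 4-methoxyphenyl on a nitrogen on an aromatic ring, and the step it made was a 1.3-fold higher number from compound 1 to compound 3 (0.12 log units; within the scatter). Compound 2 and compound 3 are not joined by a single change, and their two values also sit within the scatter of each other.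

Compound 4 `CCOC(=O)c1c(-c2ccc(C)cc2)cc(-c2ccccc2)nc1N` has not been measured in this assay . Going by the values given here, it differs from compound 3 by methyl in place of fluoro on an aromatic carbon, which is the same change as the one from compound 1 to compound 2, made at the same kind of place. The two cores, that of compound 1 and that of compound 3, differ by hydrogen in place of 4-methoxyphenyl on a nitrogen on an aromatic ring. Since the earlier step was a 1.1-fold lower number from compound 1 to compound 2 (0.04 log units; within the scatter), compound 4 is expected to show a step of about a 1.1-fold lower number from compound 3 to compound 4 (0.04 log units; within the scatter), resting on that single precedent within the scatter. Compound 4 is therefore estimated at 305000 nM, between 150000 nM and 650000 nM.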

Compound 4, half-maximal inhibitory concentration: 327000 nM
Compound 4: the middle estimate sits 1.1-fold (0.03 log units) below what was measured; the measured number falls inside the stated range.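

In this assay, methyl in place of fluoro gave a 1.0-fold lower number from compound 3 to compound 4 (0.01 log units; within the scatter), and this agrees with the same change made on the other core: the same change on two cores in this assay, a 1.1-fold lower number (0.04 log units; within the scatter) from compound 1 to compound 2 and a 1.0-fold lower number (0.01 log units; within the scatter) from compound 3 to compound 4, 1.1-fold (0.03 log units) apart, within the scatter of two such steps

Hydrogen in place of 4-methoxyphenyl on the nitrogen gave a 1.4-fold higher number from compound 2 to compound 4 (0.15 log units; within the scatter), and this also agrees with its earlier counterpart: the same change on two cores in this assay, a 1.3-fold higher number (0.12 log units; within the scatter) from compound 1 to compound 3 and a 1.4-fold higher number (0.15 log units; within the scatter) from compound 2 to compound 4, 1.1-fold (0.03 log units) apart, within the scatter of two such steps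

Both changes therefore read the same on the two cores, but every step shown lies within the scatter, so this shows only that neither change moved the number measurably on either core, and it does not show that a change with a step beyond the scatter would carry from one core to another in this series.

The compounds shown leave open whether any change to this series can move the number beyond the scatter, since all of them give high numbers that cannot be set apart. From the compounds shown here alone, what a carboxylic acid or an amide would do in place of the ethyl ester, or an amine or a longer chain on the nitrogen, also remains open.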